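The source may report more compounds than this note shows. Statements on the series, on what has been measured and on what is new or still open speak of the compounds shown alone.

Of the compounds shown here, three sharing one core have been measured in a functional assay on JAR cells (Homo sapiens) for inhibition, read by MTT assay, with a stated time of 72 h, tested at 10 uM; a lower number here means less inhibition, a higher number more inhibition at the concentration tested (going by the name of the read-out). Compound 1 `CCOC(=O)C1=C(Nc2ccccc2)S/C(=C\c2ccc(C(=O)O)cc2)C1=O` gives 16.8%, compound 2 `CCOC(=O)C1=C(Nc2ccccc2)S/C(=C\c2ccccc2O)C1=O` gives 89.4%, and compound 3 `CCOC(=O)C1=C(Nc2ccccc2)S/C(=C\c2ccc[nH]2)C1=O` gives 49.2%. Compound 3 thus stands second highest of the three, with compound 1 nearest to it and compound 2 furthest from it. All three measured steps change the group on the double-bonded chain carbon bound to the double-bonded ring carbon: a number 72.6 percentage points higher from compound 1 to compound 2 (beyond the scatter), a number 32.4 percentage points higher from compound 1 to compound 3 (beyond the scatter), and a number 40.2 percentage points lower from compound 2 to compound 3 (beyond the scatter).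

Compound 4 `CCOC(=O)C1=C(Nc2cccc(F)c2)S/C(=C\c2ccc[nH]2)C1=O` differs from compound 3 elsewhere, on the anilino part of the core: fluoro in place of hydrogen on an aromatic carbon. Among the measured compounds shown here, none of the measured steps touches that phenyl, so none bears directly on this change; the three steps, large as they are, show only that the group on the chain carbon matters, and nothing about what a fluoro on the anilino phenyl does. Without such a precedent, no step beyond the scatter is expected, and the estimated step is a number 0.8 percentage points higher from compound 3 to compound 4 (within the scatter). In this assay compound 4 is therefore expected to give about 50%, within a range from 30% to 70%.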

Compound 4, a percentage reported as inhibition, at one concentration (the size of the read-out at that concentration, not a potency): 45.4%
For compound 4 the middle estimate is 4.6 percentage points above the measured one, within the range that was stated.
By their numbers in this assay, from the lowest: compound 1; then compounds 4 and 3 (each within the scatter of the next); then compound 2.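

In this assay, adding a fluoro to the anilino phenyl, on an aromatic carbon meta to a large group, gives a number 3.8 percentage points lower from compound 3 to compound 4 (within the scatter). Among the compounds shown here, this is the first measured change on that phenyl, and it shows that this position can carry a fluoro without a shift beyond the usual scatter, at least with the 1H-pyrrol-2-yl group on the chain carbon. That contrasts with exchanging the group on the chain carbon, which can give a step as large as a number 72.6 percentage points higher from compound 1 to compound 2 (beyond the scatter), although nothing shown explains the outcome of the fluoro change.

From the compounds shown here alone, it remains open whether a fluoro on this phenyl would read the same way with the 2-hydroxyphenyl group of compound 2, which gives 89.4% in this assay, or with the fluoro on another carbon of the phenyl. Also open, going by these compounds, is what a methoxy, an amine or a carboxylic acid would do in place of the fluoro, and what would follow from replacing the ethyl ester of the shared core with an amide.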